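This account rests on a few compounds, and the source may have more. Where it says the series, first, only, none or still open, it means among the compounds named here.

In an assay on HEK-293T cells for antagonist activity at vitamin D3 receptor (Homo sapiens), read by a luciferase reporter, with a stated time of 24 h (on this read-out lower numbers stand for stronger inhibition and higher numbers for weaker inhibition), compound 1 `CCC(CC)n1c(-c2ccc(OCc3c(-c4c(Cl)cccc4Cl)noc3C(C)C)cc2F)nc2ccc(C(=O)O)cc21` gives only a limit, > 10000 nM. Compound 2 `CC(C)c1onc(-c2c(Cl)cccc2Cl)c1COc1ccc(-c2nc3ccc(C(=O)O)cc3n2Cc2ccc(F)cc2)cc1` gives 1140 nM in this assay. Among the measured compounds shown here, compound 3 `CC(C)c1onc(-c2c(Cl)cccc2Cl)c1COc1ccc(-c2nc3ccc(C(=O)O)cc3n2CC(C)(C)C)cc1` gives 861 nM in this assay, the single measured step that reaches it being a 1.3-fold lower number from compound 2 to compound 3 (0.12 log units; within the scatter); its number therefore sits within the scatter of that of compound 2. For the measured compounds named here, the only other value shown, that of compound 1, is a limit. Compound 4 `CC(C)c1onc(-c2c(Cl)cccc2Cl)c1COc1ccc(-c2nc3ccc(C(=O)O)cc3n2CC2CCCCC2)cc1` differs from compound 3 by cyclohexyl in place of tert-butyl on a saturated chain carbon bound to an aromatic nitrogen. Going by the values given here, the one step at this position, from compound 2 to compound 3, stayed within the scatter, so no change beyond the scatter is expected here either, a 1.2-fold lower number from compound 3 to compound 4 (0.09 log units; within the scatter). Compound 4 is thus estimated at 700 nM in this assay, between 250 nM and 2000 nM.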

Compound 4, half-maximal inhibitory concentration: 346 nM
For compound 4 the middle estimate is 2.0-fold (0.31 log units) above the measured one, and the stated range covers the measured number.
By their numbers in this assay, from the lowest: compound 4; then compounds 3 and 2 (each within the scatter of the next). At a limit, above all of these: compound 1.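

At this position, on a saturated chain carbon bound to an aromatic nitrogen, a change now moves the number beyond the scatter: there is a 2.5-fold lower number from compound 3 to compound 4 (0.40 log units; beyond the scatter) and also a 3.3-fold lower number from compound 2 to compound 4 (0.52 log units; beyond the scatter). The position is therefore not indifferent to its group, although the earlier step here stayed within the scatter, and cyclohexyl stands apart from both tert-butyl and 4-fluorophenyl. Nothing at hand explains this difference. Still open, as far as these compounds go, is whether a cyclopentyl ring, a longer chain or an amine at this position would give a lower number than cyclohexyl.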